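Salicylic acid azoles in the rat paw edema test

The source may hold more compounds than are shown below. What is called first, only, known or untested is meant among the compounds shown, and "the series" means these compounds.

Compound 1 `O=C(O)c1cc(-c2cc[nH]n2)ccc1O`: > 250 mg/kg
Compound 2 `O=C(O)c1cc(-c2ncccn2)ccc1O`: 100 mg/kg

In a functional assay on the whole organism for inhibition, with Rattus norvegicus as the target, read by paw edema (a lower number here means that less compound is needed, a higher number that more compound is needed for the effect), compound 1 gives only a limit, > 250 mg/kg, and no number. Compound 1 thus sits at the limit of > 250 mg/kg in this assay, at which 1 of the 2 values shown sits. Compound 2 gives 100 mg/kg in this assay. Compound 3 `O=C(O)c1cc(-n2cnnc2)ccc1O` has not been measured; it carries 4H-1,2,4-triazol-4-yl in place of 1H-pyrazol-3-yl on an aromatic carbon. With compound 1 known only as a limit, the step from compound 1 to compound 3 is expected to be an at least 1.2-fold lower number from compound 1 to compound 3 (0.09 log units; that floor lies within the scatter), in the direction of less compound needed, though likely within the scatter. Compound 3 is estimated at 200 mg/kg, between 80 mg/kg and 500 mg/kg.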

Compound 3, dose for half-maximal effect: > 250 mg/kg
Compound 3: only a limit was reported; the forecaster's own chance of this, stated with the estimate: 50%; middle value at least 1.2-fold (0.09 log units) away from the limit.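

Compound 1 and compound 3 are both known only as limits, so no step can be read between them in this assay. The compounds shown leave open whether 4H-1,2,4-triazol-4-yl and 1H-pyrazol-3-yl differ at all on the shared core.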